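Compound 1: isopropyl cut to methyl on the ring carbon

The source may report more compounds than this note shows. Statements on the series, on what has been measured and on what is new or still open speak of the compounds shown alone.

In a functional assay on SK-BR-3 cells (Homo sapiens) for inhibition (a lower number here means a stronger inhibitor, a higher number a weaker inhibitor), compound 1 (`COc1c(C)cnc(CN2c3nc(N)nc(Cl)c3NC(=O)[C@@H]2C(C)C)c1C`) gives 430 nM, the highest of the three numbers in hand. Compound 2 (`COc1c(C)cnc(CN2c3nc(N)nc(Cl)c3N(C(C)C)C(=O)[C@@H]2C(C)C)c1C`) gives 5 nM, and compound 3 (`COc1c(C)cnc(CN2CC(=O)N(C3CCCC3)c3c(Cl)nc(N)nc32)c1C`) gives 120 nM.

Compound 4 (`COc1c(C)cnc(CN2c3nc(N)nc(Cl)c3NC(=O)[C@@H]2C)c1C`) is the next point: methyl in place of isopropyl on a saturated ring carbon. For the measured compounds named here, no measured step covers this place. Going by the values given here, the one single-place step, an 86-fold lower number from compound 1 to compound 2 (1.93 log units; beyond the scatter), is large, but it concerns isopropyl in place of hydrogen on an amide-type nitrogen, so it shows only that the series can move far. Compound 3 has no isopropyl on that ring carbon and gives 120 nM, but it differs from compound 2 in more than one place and offers only a weak hint. A moderate move towards a higher number in this assay is expected, with low confidence. The expected change is a 2.8-fold higher number from compound 1 to compound 4 (0.45 log units; beyond the scatter). Compound 4 is estimated at 1200 nM, within an expected range of 300 nM to 5000 nM.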

Compound 4, half-maximal inhibitory concentration: 250 nM
The estimate for compound 4 lay 4.8-fold (0.68 log units) above the measured number; measured number outside the range, below it.
By their numbers in this assay, from the lowest: compound 2; then compound 3; then compounds 4 and 1 (each within the scatter of the next).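

In this assay, the step of a 1.7-fold lower number from compound 1 to compound 4 (0.24 log units; within the scatter) shows that, with hydrogen on the amide-type nitrogen, methyl can stand in place of isopropyl on the saturated ring carbon with no change beyond the scatter. This position therefore does not depend on isopropyl in this setting, whereas the step of an 86-fold lower number from compound 1 to compound 2 (1.93 log units; beyond the scatter) at the amide-type nitrogen moves the number far beyond the scatter. Nothing available accounts for this result.

As far as these compounds go, it remains open whether methyl on the saturated ring carbon would hold up alongside isopropyl on the amide-type nitrogen, the combination that would pair with compound 2. A longer chain, a hydroxymethyl group or an aminomethyl group on this carbon would show how much this position tolerates.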